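The compounds below may be only part of what the source reports. "The series", "measured", "known", "first", "only" and "open" are said of these compounds alone.

Working notes on the series.

Compound 1 `COc1cccc(-c2cc(-c3ccco3)nc(N)n2)c1` gives 61.4 nM in an assay on membranes from brain (strain Sprague-Dawley) for displacement of a labelled ligand from adenosine receptor A1 (Rattus norvegicus), read by scintillation counting, with a stated time of 1 h; a higher number here means a weaker inhibitor, a lower number a stronger inhibitor. Compound 2 `COc1cccc(-c2cc(-c3ccc(C)o3)nc(N)n2)c1` carries a methyl on the five-membered ring and gives 145 nM; the step of a 2.4-fold higher number from compound 1 to compound 2 (0.37 log units; beyond the scatter). Compound 3 `COc1ccc(-c2cc(-c3ccc(C)o3)nc(N)n2)cc1OC` adds a methoxy on the six-membered ring and gives 650 nM; the step of a 4.5-fold higher number from compound 2 to compound 3 (0.65 log units; beyond the scatter). Among the three numbers compound 2 stands second highest, between compound 1 and compound 3, with both gaps beyond the scatter.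

Compound 4 `Cc1ccc(-c2cc(-c3cccc(C(=O)N4CCCC4)c3)nc(N)n2)o1` differs from compound 2 in one place: (pyrrolidin-1-yl)carbonyl in place of methoxy on an aromatic carbon, placed on an aromatic carbon of a six-membered aromatic ring of carbon only, meta to a large group. Going by the values given here, no measured step covers a change at this position; the methoxy sits there in every measured compound. The nearest bearing is the step from compound 2 to compound 3, where a methoxy entering the six-membered ring raised the number modestly, and the step from compound 1 to compound 2, where a methyl entering raised it less. Both measured additions on the core raised the number, so a larger group entering here is expected to leave the number unchanged or raise it modestly, with wide uncertainty. For compound 4 the expected step is a 1.4-fold higher number from compound 2 to compound 4 (0.14 log units; within the scatter), giving an estimate of 200 nM with a range from 50 nM to 800 nM.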

Compound 4, inhibition constant: 36.8 nM
Compound 4: middle estimate off by 5.4-fold (0.74 log units), on the high side, outside the stated range (below it).
By their numbers in this assay, from the lowest: compounds 4 and 1 (each within the scatter of the next); then compound 2; then compound 3.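

In this assay, the position on the six-membered ring that held the methoxy in every earlier compound tolerates a far larger group: the exchange for (pyrrolidin-1-yl)carbonyl, 7 heavy atoms in place of 2, gives a 3.9-fold lower number from compound 2 to compound 4 (0.60 log units; beyond the scatter). This is the only step shown that lowers the number, whereas the methyl and the added methoxy both raised it, so the rise seen with those two changes does not extend to this exchange. The hydrogen-bond counts under comparison are the same for both groups, and nothing measured on hand accounts for the lower number.

On these data alone, it remains open whether the step belongs to the carbonyl or to the pyrrolidine ring, a question that a piperidine amide, an open-chain diethylamide or a plain ketone at this position would help separate. As far as these compounds go, it is also open whether the same exchange carries over to compound 1, which lacks the methyl on the five-membered ring, and how a carboxylic acid or an amine would behave at this position.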